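From Fluoro to 3-Hydroxypropyl on a Shared Core

A few compounds are considered here, and "the series" means these few. Any claim that something is new, unique, unknown or untested is made for them only; others in the source may bear on it.

Of the compounds shown here, three built on a shared core have been measured in an ADME assay on microsomes from liver (Homo sapiens) for metabolic stability, with a stated time of 10 min; a lower number here means that less of the compound is left, a higher number that more of the compound is left. Compound 1 `Fc1ccccc1-c1ccc2[nH]c(C3=NOC4(CCCCC4)C3)nc2c1` gives 79%. Compound 2 `Fc1cc(-c2ccccc2C(F)(F)F)cc2nc(C3=NOC4(CCCCC4)C3)[nH]c12` gives 46%, and compound 3 `FC(F)(F)Oc1ccccc1-c1cc(C(F)(F)F)c2[nH]c(C3=NOC4(CCCCC4)C3)nc2c1` gives 51%. Compound 2 and compound 3 therefore stand level within the scatter, while the gap between compound 2 and compound 1 lies beyond it.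

Compound 4 `OCCCc1cc(-c2ccccc2C(F)(F)F)cc2nc(C3=NOC4(CCCCC4)C3)[nH]c12` departs from compound 2 at a single place, with 3-hydroxypropyl in place of fluoro on an aromatic carbon, ortho to a fused ring and meta to a 2-(trifluoromethyl)phenyl group (3-hydroxypropyl in place of fluoro on an aromatic carbon). Going by the values given here, no measured pair of compounds isolates a change at this place, so the data offer no direct guide to its size. The closest anchor is compound 2 itself at 46%, and the expectation stays near that level, with a slight lean downward. In this assay the expected change is a number 5 percentage points lower from compound 2 to compound 4 (within the scatter), a small fall that would stay within the scatter, although a larger move in either direction cannot be ruled out. For compound 4 the estimated value is 41%, with an expected range of 22% to 62%.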

Compound 4, percent of the compound remaining: 57%
The estimate for compound 4 lay 16 percentage points below the measured number; the measured number falls inside the stated range.
By their numbers in this assay, from the lowest: compounds 2, 3 and 4 (each within the scatter of the next, the first and the last beyond it); then compound 1.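

In this assay, the change of fluoro to 3-hydroxypropyl on an aromatic carbon, ortho to a fused ring and meta to a 2-(trifluoromethyl)phenyl group, gives a number 11 percentage points higher from compound 2 to compound 4 (beyond the scatter) as a modest step. Going by these compounds alone, the earlier compounds contained no pair differing at this place, so this is the first direct reading of the position, and it shows that the larger 3-hydroxypropyl group can stand there without less of the compound being left. This reading rests on a single pair of compounds, and no available measurement bears on why the number moved.

Going by these compounds, it remains open whether the step follows the hydroxyl end of the chain or the chain itself, a question that a plain propyl group or a longer chain at the same place could help to separate. Also open, on these data alone, are how an amine or a carboxylic acid at the end of the chain would read in this assay and whether the fluoro to 3-hydroxypropyl step would hold with a different group in place of the 2-(trifluoromethyl)phenyl group.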